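Replacing 4-fluorophenyl with 3-methylphenyl: compound 2 to compound 3

The source may report more compounds than this note shows. Statements on the series, on what has been measured and on what is new or still open speak of the compounds shown alone.

- Compound 1 `OCCCCCC(O)c1ccc(-c2ccccc2)cc1`: 22000 nM
- Compound 2 `OCCCCCC(O)c1ccc(-c2ccc(F)cc2)cc1`: 18000 nM

In a functional assay on J774 cells (Mus musculus) for cytotoxicity, read by resazurin assay (a lower number here means a stronger inhibitor, a higher number a weaker inhibitor), compound 2 gives 18000 nM, which lies within the scatter of the value for compound 1. Compound 3 `Cc1cccc(-c2ccc(C(O)CCCCCO)cc2)c1` carries 3-methylphenyl in place of 4-fluorophenyl on an aromatic carbon. Among the compounds with values here, the only measured step that bears on this change is a 1.2-fold lower number from compound 1 to compound 2 (0.09 log units; within the scatter), a fluoro in place of a hydrogen. Within the data shown here, no measured compound carries a methyl group, so the evidence is thin, and no change beyond the scatter is expected. The expected step is a 1.1-fold lower number from compound 2 to compound 3 (0.05 log units; within the scatter). For compound 3 the estimated value is 16000 nM, with an expected range from 8000 nM to 32000 nM.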

Compound 3, half-maximal inhibitory concentration: > 100000 nM
Compound 3: no number, only a limit; the forecaster's own chance of this, stated with the estimate: 5%; middle value at least 6.2-fold (0.79 log units) away from the limit.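

In this assay compound 3 gives no number but a limit of the assay: the limit of > 100000 nM in this assay, at which 1 of the 3 values shown sits.

Where fluoro left the reading within the scatter, an at least 5.5-fold higher number from compound 2 to compound 3 (0.74 log units; beyond the scatter) and an at least 4.5-fold higher number from compound 1 to compound 3 (0.65 log units; beyond the scatter) both lie beyond it. A change on this aromatic ring can therefore move the reading, and 3-methylphenyl is the first group shown to do so.

On these data alone, whether the methyl group itself or its place on the ring sets this step stays open. So does what an amine or a methoxy group on the same ring would give.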